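A few compounds are considered here, and "the series" means these few. Any claim that something is new, unique, unknown or untested is made for them only; others in the source may bear on it.

Measured compounds, all in a functional assay on Caco-2 cells (Homo sapiens) for antiproliferative activity, read by MTT assay, with a stated time of 48 h; a higher number here means a weaker inhibitor, a lower number a stronger inhibitor
Compound 1 `CCn1c(C(=O)NCCN)ccc1C(CC)(CC)c1ccc(OCCC(O)(CC)CC)c(C)c1` gives 1740 nM
Compound 2 `CCn1c(C(=O)Nc2cccc(C(F)(F)F)c2)ccc1C(CC)(CC)c1ccc(OCCC(O)(CC)CC)c(C)c1` gives > 50000 nM (a limit of the assay)
Compound 3 `CCOC(=O)C(CC(=O)OC)NC(=O)c1ccc(C(CC)(CC)c2ccc(OCCC(O)(CC)CC)c(C)c2)n1CC` gives 3020 nM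

Compound 3 stands level with compound 1, the gap being a 1.7-fold higher number from compound 1 to compound 3 (0.24 log units; within the scatter). For compound 2 the assay returns only a limit, > 50000 nM.

Compound 4 `CCn1c(C(=O)N(C)CCO)ccc1C(CC)(CC)c1ccc(OCCC(O)(CC)CC)c(C)c1` differs from compound 3 at the carbonyl carbon, where a (2-hydroxyethyl)(methyl)amino group takes over: a group of 5 heavy atoms (3 carbon, 1 nitrogen, 1 oxygen; no ring) in place of a group of 12 heavy atoms (7 carbon, 1 nitrogen, 4 oxygen; no ring), on a carbonyl carbon.

The closest guide is the exchange of one ring-free group for another, which stayed within the scatter: a 1.7-fold higher number from compound 1 to compound 3 (0.24 log units; within the scatter). The two large steps, an at least 28-fold higher number from compound 1 to compound 2 (1.45 log units; beyond the scatter) and an at least 16-fold lower number from compound 2 to compound 3 (1.21 log units; beyond the scatter), both involve the 3-(trifluoromethyl)phenyl group of compound 2, and compound 4 has no ring in this group. In this assay, no step beyond the scatter is therefore expected. Compounds 1, 2 and 3 all keep the amide hydrogen and compound 4 lacks it, so the range stays wide.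

The expected change is a 1.1-fold lower number from compound 3 to compound 4 (0.03 log units; within the scatter).

Compound 4 is estimated at 2800 nM, with an expected range of 900 nM to 10000 nM.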

Compound 4, half-maximal inhibitory concentration: 74 nM
Compound 4: the middle estimate sits 38-fold (1.58 log units) above what was measured; measured number outside the range, below it.
By their numbers in this assay, from the lowest: compound 4; then compounds 1 and 3 (each within the scatter of the next). At a limit, above all of these: compound 2.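

In this assay, a ring-free group on this carbonyl carbon can move the number far beyond the scatter, as (2-hydroxyethyl)(methyl)amino gives a 41-fold lower number from compound 3 to compound 4 (1.61 log units; beyond the scatter) and a 24-fold lower number from compound 1 to compound 4 (1.37 log units; beyond the scatter), whereas the earlier ring-free exchange gave only a 1.7-fold higher number from compound 1 to compound 3 (0.24 log units; within the scatter). Compound 4 now has the lowest number of the series, and it is also the only compound shown that lacks the amide hydrogen. The third step, an at least 670-fold lower number from compound 2 to compound 4 (2.82 log units; beyond the scatter), is only a bound, as it rests on a limit: the limit of > 50000 nM in this assay, at which 1 of the 4 values shown sits.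

The compounds shown leave open whether the lower number goes with the methyl on the amide nitrogen, with the hydroxyl, or with both together. A (2-hydroxyethyl)amino group or a dimethylamino group on the same carbonyl carbon would separate these two features.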